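This account rests on a few compounds, and the source may have more. Where it says the series, first, only, none or still open, it means among the compounds named here.

Compound 1, `Cc1c(CO)cc2n1[C@@H](c1ccccc1)SC2`: 36800 nM
Compound 2, `Cc1cc(CO)c2n1[C@@H](c1ccccc1)SC2`: 45300 nM

Both were tested in a functional assay on A-375 cells (Homo sapiens) for cytotoxicity, read by MTT assay, with a stated time of 96 h; a lower number here means a stronger inhibitor, a higher number a weaker inhibitor. Compound 2 gives 45300 nM, and compound 1 gives 36800 nM; these two numbers lie within the usual scatter of each other, so neither compound can be set apart from the other. Compound 3, `Cc1c(CO)c(CO)c2n1[C@@H](c1ccccc1)SC2`, differs from compound 2 in one place: hydroxymethyl in place of hydrogen on an aromatic carbon. Going by the values given here, no pair of measured compounds shows this change, so nothing here points to a step in either direction beyond the scatter. Compound 3 is therefore expected to give 42000 nM, with a range from 15000 nM to 120000 nM. The expected step is a 1.1-fold lower number from compound 2 to compound 3 (0.03 log units; within the scatter).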

Compound 3, half-maximal inhibitory concentration: 16900 nM
For compound 3 the middle estimate is 2.5-fold (0.40 log units) above the measured one, within the range that was stated.
By their numbers in this assay, from the lowest: compound 3; then compounds 1 and 2 (each within the scatter of the next).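

Adding a hydroxymethyl group to the five-membered aromatic ring of compound 2 gives a 2.7-fold lower number from compound 2 to compound 3 (0.43 log units; beyond the scatter) in this assay, and the matching addition also gives a 2.2-fold lower number from compound 1 to compound 3 (0.34 log units; beyond the scatter) in the same test. Both steps are modest but beyond the scatter, so having both hydroxymethyl groups on the ring sets compound 3 apart, which compound 1 and compound 2 alone could not show. Nothing measured here explains this gain. Still open, from the compounds shown here alone, is whether a hydrogen-replacing amine, carboxylic acid or longer chain at this aromatic carbon would lower the number further or raise it.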